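The compounds below may be only part of what the source reports. "The series", "measured", "known", "first", "only" and "open" are said of these compounds alone.

Compound 1 `COc1ccc(NC(=O)CN2CCN(S(=O)(=O)N3CCC(C)CC3)CC2)cc1` gives in an assay on HEK293 cells for activation of potassium channel subfamily T member 1 (Homo sapiens), read by thallium flux (on this read-out lower numbers stand for an effect already at smaller amounts and higher numbers for an effect only at larger amounts of compound), only a limit, > 10000 nM.
Compound 2 `Cc1ccc(NC(=O)CN2CCN(S(=O)(=O)N3CCC(C)CC3)CC2)cc1` gives in this assay 4100 nM.
Compound 3 `CC1CCN(S(=O)(=O)N2CCN(CC(=O)Nc3cccc(F)c3)CC2)CC1` gives in this assay 4600 nM.

Of the two compounds with a number, compound 3 has the higher one, though the gap a 1.1-fold higher number from compound 2 to compound 3 (0.05 log units; within the scatter) lies within the scatter; compound 1 sits at the limit (the limit of > 10000 nM in this assay, at which 1 of the 3 values shown sits). Compound 4 `CC1CCN(S(=O)(=O)N2CCN(CC(=O)Nc3ccc(F)cc3)CC2)CC1` differs from compound 3 only in 4-fluorophenyl in place of 3-fluorophenyl on an amide-type nitrogen. Among the compounds with values here, no measured step moves a fluorine between positions on that ring. The steps that touch the same nitrogen are an at least 2.1-fold lower number from compound 1 to compound 3 (0.33 log units; beyond the scatter) and a 1.1-fold higher number from compound 2 to compound 3 (0.05 log units; within the scatter), the second within the scatter, beside an at least 2.4-fold lower number from compound 1 to compound 2 (0.38 log units; beyond the scatter) on the other ring. None of them bears directly on compound 4, so no step beyond the scatter is expected in this assay, a 1.0-fold lower number from compound 3 to compound 4 (0.01 log units; within the scatter). Compound 4 is therefore estimated at 4500 nM, between 1500 nM and 15000 nM.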

Compound 4, half-maximal effective concentration: > 10000 nM
Compound 4 ended at the assay's limit; the forecaster's own chance of this, stated with the estimate: 25%; middle value at least 2.2-fold (0.34 log units) from the limit.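

In this assay, the place of the fluorine on the phenyl ring matters even though the atoms stay the same: 4-fluorophenyl in place of 3-fluorophenyl on the amide-type nitrogen gives an at least 2.1-fold higher number from compound 3 to compound 4 (0.33 log units; beyond the scatter). Fluoro in place of methyl on an aromatic carbon gives an at least 2.4-fold higher number from compound 2 to compound 4 (0.38 log units; beyond the scatter), so this change also counts when the group keeps its place on the ring. The step from compound 1 to compound 4 cannot be read, both values being limits: the limit of > 10000 nM in this assay, at which 2 of the 4 values shown sit.

As far as these compounds go, whether a chloro or a nitrile group on that phenyl ring would follow fluoro or methyl remains open.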